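This account rests on a few compounds, and the source may have more. Where it says the series, first, only, none or still open, it means among the compounds named here.

Series notes. Compound 1 `CC1=C(/C=C/C(=O)/C=C/c2ccccc2)C(C)(C)CCC1O` gives 8000 nM in a functional assay on CWR22R cells (Homo sapiens) for cytotoxicity, read by MTT assay, with a stated time of 72 h; on this read-out higher numbers stand for weaker inhibition and lower numbers for stronger inhibition. Compound 2 `CC1=C(/C=C/C(=O)/C=C/c2ccccc2C(F)(F)F)C(C)(C)CCC1O` differs from compound 1 by trifluoromethyl in place of hydrogen on an aromatic carbon; in this assay compound 2 gives 2300 nM, the step being a 3.5-fold lower number from compound 1 to compound 2 (0.54 log units; beyond the scatter). Compound 3 `CC1=C(/C=C/C(=O)/C=C/c2ccc(F)cc2)C(C)(C)CCC1O` differs from compound 1 by fluoro in place of hydrogen on an aromatic carbon; in this assay compound 3 gives 7500 nM, a step of a 1.1-fold lower number from compound 1 to compound 3 (0.03 log units; within the scatter). Compound 4 `CC1=C(/C=C/C(=O)/C=C/c2ccc(F)c(C(F)(F)F)c2)C(C)(C)CCC1O` differs from compound 3 by trifluoromethyl in place of hydrogen on an aromatic carbon. This is the same kind of change as from compound 1 to compound 2, not the same one: in compound 2 the entering group sits ortho to a large group, whereas in compound 4 it sits ortho to a fluoro group and meta to a large group. Among the compounds with values here, only one measured instance of this kind of change exists, so the expectation for compound 4 rests on a 3.5-fold lower number from compound 1 to compound 2 (0.54 log units; beyond the scatter) alone, with the different surroundings noted. In this assay compound 4 is expected to give 3000 nM, between 1200 nM and 8000 nM. The expected step is a 2.5-fold lower number from compound 3 to compound 4 (0.40 log units; beyond the scatter).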

Compound 4, half-maximal inhibitory concentration: 3200 nM
The estimate for compound 4 lay 1.1-fold (0.03 log units) below the measured number, within the range that was stated.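

Trifluoromethyl in place of hydrogen on an aromatic carbon again goes with a step in the same direction in this assay, here a 2.3-fold lower number from compound 3 to compound 4 (0.37 log units; beyond the scatter). Set beside the earlier instance, the change carries across the two cores at a similar size: the same change on two cores in this assay, a 3.5-fold lower number (0.54 log units; beyond the scatter) from compound 1 to compound 2 and a 2.3-fold lower number (0.37 log units; beyond the scatter) from compound 3 to compound 4, 1.5-fold (0.17 log units) apart, within the scatter of two such steps. This rests on two pairs only, with the entering group in different surroundings, so it does not show that the step would carry to other cores in the series.

The compounds shown leave open whether a nitrile, a methoxy group or an amine on the aromatic carbon ortho to a fluoro group would give a step of like size. Changes at the hydroxyl of the shared core also remain open.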